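Bicyclic replacement for pyrimidinyl on the sulfur linker

A few compounds are considered here, and "the series" means these few. Any claim that something is new, unique, unknown or untested is made for them only; others in the source may bear on it.

In an assay on microsomes from liver for inhibition of sterol O-acyltransferase 1 (Rattus norvegicus) (on this read-out higher numbers stand for weaker inhibition and lower numbers for stronger inhibition), compound 3 `CCCCCCCN(CCCCCSc1ncccn1)C(=O)Nc1ccc(F)cc1F` gives 3300 nM and stands highest of the three measured compounds. Compound 2 `CCCCCCN(CCCCCSc1nc2cc([N+](=O)[O-])ccc2[nH]1)C(=O)Nc1ccc(F)cc1F` gives 2000 nM in this assay, a gap within the scatter. Compound 1 `CCCCCCN(CCCCCSc1nc2c([nH]1)CCCC2)C(=O)Nc1ccc(F)cc1F` gives 810 nM in this assay, a gap to compound 3 that lies beyond the scatter; compound 1 and compound 3 differ in two places, so the gap is not attributed to either alone.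

Compound 4 `CCCCCCCN(CCCCCSc1[nH]cnc2nncc1-2)C(=O)Nc1ccc(F)cc1F` is to be measured in this assay. Relative to compound 3 it carries a group of 9 heavy atoms (5 carbon, 4 nitrogen; one five-membered aromatic ring with 2 hetero atoms, one six-membered aromatic ring with 2 hetero atoms) in place of a group of 6 heavy atoms (4 carbon, 2 nitrogen; one six-membered aromatic ring with 2 hetero atoms), on a sulfur. For the measured compounds named here, the only measured step at the same place is a 2.5-fold higher number from compound 1 to compound 2 (0.39 log units; beyond the scatter), a swap between two bicyclic heteroaryls. Going by the values given here, no measured step isolates a move from the monocyclic pyrimidin-2-yl to a bicyclic group with a hydrogen-bond donor, though compound 1, which carries a five-membered aromatic ring with a ring hydrogen, gives the lowest number in the set.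

The expectation for compound 4 is therefore a modest step in this assay toward a lower number, a 2.2-fold lower number from compound 3 to compound 4 (0.34 log units; beyond the scatter), with wide uncertainty because the series shows at most one step on this position. Compound 4 is estimated at 1500 nM, within a range of 500 nM to 4500 nM.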

Compound 4, half-maximal inhibitory concentration: 710 nM
For compound 4 the middle estimate is 2.1-fold (0.32 log units) above the measured one; measured number inside the range.
By their numbers in this assay, from the lowest: compounds 4 and 1 (each within the scatter of the next); then compounds 2 and 3 (each within the scatter of the next).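

In this assay, for the compounds shown here, a 4.6-fold lower number from compound 3 to compound 4 (0.67 log units; beyond the scatter) gives the first reading at this position of a move from pyrimidin-2-yl to a bicyclic group, with the rest of the molecule unchanged. Together with a 2.5-fold higher number from compound 1 to compound 2 (0.39 log units; beyond the scatter), which swaps one bicyclic group for another, this shows that the number responds to the group on the sulfur both when a bicyclic group replaces the monocycle and when one bicyclic group replaces another. The entering group differs from pyrimidin-2-yl in its rings, heavy atoms, hydrogen-bond donors and hydrogen-bond acceptors all at once, so this single pair does not separate those changes, and no measurement at hand bears on the reason for the step.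

A monocyclic imidazol-2-yl on the same linker would show whether the five-membered aromatic ring with its ring hydrogen can carry the step without the fused six-membered ring, while an unsubstituted benzimidazol-2-yl would test the bicyclic frame with fewer ring nitrogens. As far as these compounds go, how an amine or a carboxylic acid on the bicyclic group, or a longer chain on the urea nitrogen, would change the number remains open.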